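The compounds below may be only part of what the source reports. "The series", "measured", "known", "first", "only" and "open" are said of these compounds alone.

Compound 1 `CN(C)CCn1cnnc1-c1cc(Oc2ccc(NC(=O)N/N=C/c3cccc(O)c3)cc2F)ccn1`: "not determined" (no result reported). Compound 2 `CN(C)CCn1cnnc1-c1cc(Oc2ccc(NC(=O)N/N=C/c3ccc(O)c(O)c3)cc2F)ccn1`: "not determined" (no result reported). Compound 3 `CN(C)CCn1cnnc1-c1cc(Oc2ccc(NC(=O)N/N=C/c3cc(C(C)(C)C)cc(C(C)(C)C)c3O)cc2F)ccn1`: 2350 nM.

The three compounds share one core and differ only in the aromatic group that sits on the carbon with a double bond to nitrogen. In an ADME assay on WI-38 cells (Homo sapiens) for cytotoxicity, read by MTT assay, with a stated time of 72 h (on this read-out lower numbers stand for stronger inhibition and higher numbers for weaker inhibition), compound 3 gives 2350 nM. For compound 1 and for compound 2 no number is reported in this assay, so compound 2 has no value of its own to stand on. Compound 4 `COc1ccc(/C=N/NC(=O)Nc2ccc(Oc3ccnc(-c4nncn4CCN(C)C)c3)c(F)c2)c(OC)c1` has not yet been tested; against compound 2 it carries 2,4-dimethoxyphenyl in place of 3,4-dihydroxyphenyl on a carbon with a double bond to nitrogen. No measured step joins any two of these compounds in this assay, so the size of the change cannot be read from data; the expectation is a value close to that of compound 3, with no clear direction beyond the scatter. Compound 4 is estimated at 5000 nM, within a range from 1500 nM to 18000 nM, because compound 3 gives 2350 nM.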

Compound 4, half-maximal inhibitory concentration: 6630 nM
Beside the measured number, compound 4's estimate is 1.3-fold (0.12 log units) below it, and the stated range covers the measured number.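

No step can be read from compound 2 to compound 4, and no measured evidence explains the value of compound 4. The compounds shown leave open how much the swap from 3,4-dihydroxyphenyl to 2,4-dimethoxyphenyl shifts the result.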